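From an aryl ether to a free alcohol at the limit

The compounds below may be only part of what the source reports. "The series", "measured", "known", "first", "only" and "open" are said of these compounds alone.

In a functional assay on A549 cells (Homo sapiens) for cytotoxicity, read by MTT assay, with a stated time of 48 h (on this read-out lower numbers stand for stronger inhibition and higher numbers for weaker inhibition), compound 2 `Cc1ccc(OCc2cn(-c3ccc(S(=O)(=O)N4CCc5ccccc5C4)cc3)nn2)cc1` gives > 50 ug/mL, which is a limit of the assay and not a number. Compound 1 `COc1cc2c(cc1OC)CN(S(=O)(=O)c1ccc(-n3cc(COc4ccccc4C(C)=O)nn3)cc1)CC2` gives > 50 ug/mL, also a limit. Compound 3 `COc1cc2c(cc1OC)CN(S(=O)(=O)c1ccc(-n3cc(COc4ccc(C=O)cc4OC)nn3)cc1)CC2` gives > 50 ug/mL, again a limit. Compound 2 therefore has no exact place in the series, and the evidence so far is the limit of > 50 ug/mL in this assay, at which 3 of the 3 values shown sit. For the measured compounds named here, the one measured step is a step that the two limits leave unreadable from compound 1 to compound 3.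

Compound 4 `O=S(=O)(c1ccc(-n2cc(CO)nn2)cc1)N1CCc2ccccc2C1` has not yet been measured. It differs from compound 2 as follows: hydrogen in place of 4-methylphenyl on an oxygen on a saturated carbon. In other words, 4-methylphenoxy gives way to hydroxy, on a saturated carbon.

Going by the values given here, no measured step gives a size for this change, since a step that the two limits leave unreadable from compound 1 to compound 3 offers only limits. No direction can be argued from the series, and a further reading at the limit is the likeliest outcome. The step expected is a step that the limit leaves unreadable from compound 2 to compound 4, with no movement beyond the scatter anticipated. The estimate for compound 4 is 70 ug/mL, with an expected range of 30 ug/mL to 150 ug/mL.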

Compound 4, half-maximal inhibitory concentration: > 50 ug/mL
Compound 4: only a limit was reported; the forecaster's own chance of this, stated with the estimate: 80%; the middle value does not contradict the limit.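

In this assay compound 4 gives > 50 ug/mL, a limit of the assay and not a number, so no size can be read for the change from compound 2 to compound 4. The compounds shown leave open whether any close relative would give a measurable value, as all of them share one result: the limit of > 50 ug/mL in this assay, at which 4 of the 4 values shown sit.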